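Ring Substituent Changes on the Shared Core

The compounds below may be only part of what the source reports. "The series", "measured", "known", "first", "only" and "open" are said of these compounds alone.

Compound 1 `COC(=O)[C@@]1(C)CC[C@@H]2C3=C1CC[C@@H](C)[C@]3(C)Cc1c2[nH]c2ccccc12` gives 3200 nM in a functional assay on HeLa cells (Homo sapiens) for inhibition, read by sulforhodamine B assay, with a stated time of 48 h; on this read-out higher numbers stand for weaker inhibition of growth and lower numbers for stronger inhibition of growth. Compound 2 `COC(=O)[C@@]1(C)CC[C@@H]2C3=C1CC[C@@H](C)[C@]3(C)Cc1c2[nH]c2c(C)cccc12` gives 12000 nM in this assay, the higher of the two numbers. Among the measured compounds shown here, the only measured step is a 3.8-fold higher number from compound 1 to compound 2 (0.57 log units; beyond the scatter). Compound 3 `COC(=O)[C@@]1(C)CC[C@@H]2C3=C1CC[C@@H](C)[C@]3(C)Cc1c2[nH]c2c(Br)cccc12` carries bromo in place of methyl on an aromatic carbon. For the measured compounds named here, no measured pair sets bromo against methyl at this position; the single step from compound 1 to compound 2, modest in size, only shows that a group there can raise the number somewhat. The expected step is a 1.2-fold lower number from compound 2 to compound 3 (0.08 log units; within the scatter), nothing beyond the scatter. Compound 3 is therefore estimated at 10000 nM, within 3500 nM to 30000 nM.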

Compound 3, concentration for 50% growth inhibition: 18000 nM
The estimate for compound 3 lay 1.8-fold (0.26 log units) below the measured number; measured number inside the range.
By their numbers in this assay, from the lowest: compound 1; then compounds 2 and 3 (each within the scatter of the next).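

In this assay, bromo and methyl on this aromatic carbon cannot be told apart, with a 1.5-fold higher number from compound 2 to compound 3 (0.18 log units; within the scatter), so exchanging one for the other does not move the number beyond the scatter. Hydrogen to bromo gives a 5.6-fold higher number from compound 1 to compound 3 (0.75 log units; beyond the scatter), so among the groups shown the rise over hydrogen is not confined to methyl. No available evidence bears on the reason for this rise.

Still open, going by these compounds, is whether an amine, a hydroxyl or a carboxylic acid at this position would also give a number above that of compound 1.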